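This account rests on a few compounds, and the source may have more. Where it says the series, first, only, none or still open, it means among the compounds named here.

Compound 1 `Cc1ccc(-c2oc3ccccc3c(=O)c2C)cc1`: 102 ug/mL
Compound 2 `Cc1c(-c2ccc(N(C)C)cc2)oc2cc(O)ccc2c1=O`: 58.8 ug/mL

In a functional assay, read by spectrophotometry, with a stated time of 20 min (a higher number here means a weaker inhibitor, a lower number a stronger inhibitor), compound 1 gives 102 ug/mL and compound 2 gives 58.8 ug/mL, two numbers within the usual scatter of each other, so neither compound can be ranked above the other. Compound 3 `Cc1c(-c2ccc(F)cc2)oc2ccccc2c1=O` has fluoro in place of methyl on an aromatic carbon, para to a large group: fluoro in place of methyl on an aromatic carbon. No measured single change offers a guide here, so no shift beyond the scatter is expected in this assay, in either direction. The estimated change is a 1.1-fold lower number from compound 1 to compound 3 (0.03 log units; within the scatter). For compound 3 the expected value is 95 ug/mL, with an estimated range of 45 ug/mL to 200 ug/mL.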

Compound 3, half-maximal inhibitory concentration: 114 ug/mL
Compound 3: middle estimate off by 1.2-fold (0.08 log units), on the low side, within the range that was stated.
By their numbers in this assay, from the lowest: compounds 2, 1 and 3 (each within the scatter of the next).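

Going by these compounds alone, the swap of methyl for fluoro on an aromatic carbon, para to a large group, is the first change at a single place seen in this assay and it gives a 1.1-fold higher number from compound 1 to compound 3 (0.05 log units; within the scatter) as its result. At this position, then, the two groups cannot be told apart in this read-out. No measurement at hand offers an explanation for this. The compounds shown leave open whether a carboxylic acid or a longer chain such as propyl on this same carbon would give a step beyond the scatter.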